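The source may report more compounds than this note shows. Statements on the series, on what has been measured and on what is new or still open speak of the compounds shown alone.

In an ADME assay on L6 cells (Rattus norvegicus) for cytotoxicity (a lower number here means a stronger inhibitor, a higher number a weaker inhibitor), compound 1 `CCN(CC)c1nc(-c2ccccn2)nc(C)c1Cl` gives 148000 nM. Compound 2 `Cc1nc(-c2ccccn2)nc(NCc2ccccc2)c1Cl` gives 70100 nM, the lower of the two numbers, with a gap beyond the usual scatter. Compound 3 `Cc1nc(-c2ccccn2)nc(NCC2CCCCC2)c1Cl`, not yet measured, differs from compound 2 at one place: cyclohexyl in place of phenyl on a saturated chain carbon bound to a nitrogen on an aromatic ring. Within the data shown here, no measured pair shows this change, so only a small move towards a lower number is expected in this assay, perhaps none beyond the scatter. The estimated step is a 1.4-fold lower number from compound 2 to compound 3 (0.15 log units; within the scatter). For compound 3 the estimated value is 50000 nM, within a range of 20000 nM to 120000 nM.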

Compound 3, half-maximal inhibitory concentration: 42400 nM
The estimate for compound 3 lay 1.2-fold (0.07 log units) above the measured number; the measured number falls inside the stated range.
By their numbers in this assay, from the lowest: compounds 3 and 2 (each within the scatter of the next); then compound 1.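

On the saturated chain carbon bound to a nitrogen on an aromatic ring, cyclohexyl in place of phenyl gives a 1.7-fold lower number from compound 2 to compound 3 (0.22 log units; within the scatter) in this assay. The first step measured at this place therefore shows that replacing the aromatic ring with a non-aromatic ring of carbon only leaves compound 2 and compound 3 unresolved by this read-out. Nothing available accounts for this result. The compounds shown leave open whether a longer chain carrying the cyclohexyl, or a carboxylic acid on that ring, would shift the number beyond the scatter.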